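Benzyl for Pentyl on the Amino Side Chain

This account rests on a few compounds, and the source may have more. Where it says the series, first, only, none or still open, it means among the compounds named here.

Measured so far:
compound 1 `CCOc1ccc(C(=O)Nc2cc(C)cc(C)n2)cc1`: 17100 nM
compound 2 `CCCCCNc1cccc(NC(=O)c2ccc(OCCC)cc2)n1`: > 100000 nM

In an in vitro assay on HEK-tsA201 cells for antagonist activity at Neuronal acetylcholine receptor; alpha4/beta2 (Homo sapiens), read by fluorescence and calcium flux (on this read-out lower numbers stand for stronger inhibition and higher numbers for weaker inhibition), compound 1 gives 17100 nM. For compound 2 the assay reports only a limit, > 100000 nM, so its true value is not known (the limit of > 100000 nM in this assay, at which 1 of the 2 values shown sits). Compound 3 `CCCOc1ccc(C(=O)Nc2cccc(NCc3ccccc3)n2)cc1` differs from compound 2 by phenyl in place of butyl on a saturated chain carbon bound to a nitrogen on an aromatic ring. Within the data shown here, no measured pair shows this change, so the step has no precedent here. Since compound 2 sits at the limit, the expected step of an at least 1.2-fold lower number from compound 2 to compound 3 (0.09 log units; that floor lies within the scatter) is small and within the scatter, with a modest chance of stronger inhibition. Compound 3 is therefore estimated at 80000 nM, in a range from 20000 nM to 300000 nM.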

Compound 3, half-maximal inhibitory concentration: > 100000 nM
Compound 3 ended at the assay's limit; the forecaster's own chance of this, stated with the estimate: 55%; middle value at least 1.2-fold (0.09 log units) from the limit.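

No step can be read from compound 2 to compound 3 in this assay, because each is reported only as a limit: the limit of > 100000 nM in this assay, at which 2 of the 3 values shown sit.

The compounds shown leave open whether benzyl in place of pentyl changes inhibition at all.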